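Piperidine Sulfonamide Series: Sulfonyl Substituent Swap

The compounds below may be only part of what the source reports. "The series", "measured", "known", "first", "only" and "open" are said of these compounds alone.

Measured so far:
Compound 1 `CCN(CC)S(=O)(=O)c1ccc(S(=O)(=O)N2CCC[C@@H](C(=O)NC3CN(C(=O)OC(C)(C)C)C3)C2)cc1` — 200 nM
Compound 2 `CC(C)c1noc(N2CCN(C(=O)[C@@H]3CCCN(S(=O)(=O)c4ccc(S(=O)(=O)C5CCC5)cc4)C3)CC2)n1` — 70 nM

In a functional assay on MIA PaCa-2 cells (Homo sapiens) for inhibition, read by MTT assay, with a stated time of 7 days (a lower number here means a stronger inhibitor, a higher number a weaker inhibitor), compound 2 gives 70 nM, the lowest of the two numbers on hand. The nearest comparison is compound 1, which in this assay gives 200 nM, a gap that lies beyond the scatter; the two structures differ in more than one place, so the gap cannot be pinned to any single change.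

Compound 3 `CCNS(=O)(=O)c1ccc(S(=O)(=O)N2CCC[C@@H](C(=O)N3CCN(c4nc(C(C)C)no4)CC3)C2)cc1` is the untested follow-up to compound 2. The difference is ethylamino in place of cyclobutyl on a sulfonyl sulfur; cut one bond further out it reads cyclobutylsulfonyl to ethylsulfamoyl. The remainder of compound 2 is kept unchanged.

For the measured compounds named here, no matched step of this kind exists among the measured compounds, so the expectation rests on the size of the change alone: a small swap at the outer edge of the molecule is expected to move the number little, most likely within the scatter or toward a somewhat weaker inhibitor. The step from compound 2 to compound 3 is expected to be a 1.7-fold higher number from compound 2 to compound 3 (0.23 log units; within the scatter). For compound 3 the estimate in this assay is 120 nM, with a range from 40 nM to 400 nM.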

Compound 3, half-maximal inhibitory concentration: 3300 nM
For compound 3 the middle estimate is 28-fold (1.44 log units) below the measured one; the whole stated range lies below it.
By their numbers in this assay, from the lowest: compound 2; then compound 1; then compound 3.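

In this assay the group on the sulfonyl sulfur turns out to be far from a neutral outer edge: ethylamino in place of cyclobutyl gives a 47-fold higher number from compound 2 to compound 3 (1.67 log units; beyond the scatter) with the rest of compound 2 kept unchanged. Compound 1 and compound 2 differ in more than one place and could not isolate any single position, whereas this pair ties a large change in the read-out to this one site, on a sulfonyl sulfur whose other neighbour is aromatic carbon. Nothing on hand accounts for the size of the step, which stands as an observation without a stated cause.

The single step changes several things at once: the four-membered carbon ring leaves, and a chain with a nitrogen and a hydrogen-bond donor enters, so the compounds shown cannot say which of these carries the loss. A plain ethyl group or a cyclobutylamino group on the same sulfonyl sulfur would pull these apart, and a dimethylamino group would bear on whether the amino hydrogen matters at all.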